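From sec-butyl to butyl on a sulfur

A few compounds are considered here, and "the series" means these few. Any claim that something is new, unique, unknown or untested is made for them only; others in the source may bear on it.

In an ADME assay on MT4 cells (Homo sapiens) for activation, read by MTT assay (a lower number here means that less compound is tolerated, a higher number that more compound is tolerated), compound 3 `CCC(C)Sc1nc(C(C)c2c(F)cccc2Cl)cc(=O)[nH]1` gives > 73000 nM, which is a limit and not a number. Compound 2 `CC(C)Sc1nc(C(C)c2c(F)cccc2Cl)cc(=O)[nH]1` gives > 75000 nM, also a limit. Compound 1 `CCCCSc1nc(Cc2c(F)cccc2Cl)cc(=O)[nH]1`, which has butyl on a sulfur, gives > 76000 nM, again a limit. Compound 4 `CCCCSc1nc(C(C)c2c(F)cccc2Cl)cc(=O)[nH]1` has butyl in place of sec-butyl on a sulfur. Within the data shown here, the one measured step that bears on this change is a step that the two limits leave unreadable from compound 2 to compound 3, so it offers no size to carry over. With only limits to go on, no step beyond the usual scatter is expected in this assay. The expected change is a number no higher from compound 3 to compound 4 (the limit leaves the size open). For compound 4 the estimated value is 73000 nM, with an expected range from 35000 nM to 110000 nM.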

Compound 4, half-maximal cytotoxic concentration: > 73000 nM
Compound 4 was reported as a limit; the forecaster's own chance of this, stated with the estimate: 80%; the middle value lies on the limit itself.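

Among these compounds, compound 1, compound 2, compound 3 and compound 4 are all reported only as limits in this assay, and no step between them can be read. From the compounds shown here alone, how much of each compound is actually tolerated stays open.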